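The source may report more compounds than this note shows. Statements on the series, on what has been measured and on what is new or still open speak of the compounds shown alone.

In this study three compounds have been measured in an ADME assay on HUVEC cells (Homo sapiens) for cytotoxicity, read by MTT assay, with a stated time of 48 h (a lower number here means a stronger inhibitor, a higher number a weaker inhibitor), and a fourth awaits measurement there. Compound 1 `COc1ccc(NC(=S)OCCNC(=O)C(C)(C)Oc2ccc(Cl)cc2)cc1` gives 616000 nM in this assay. Compound 3 `Cc1ccc(NC(=S)OCCNC(=O)C(C)(C)Oc2ccc(Cl)cc2)cc1` differs from compound 1 by methyl in place of methoxy on an aromatic carbon, and in this assay compound 3 gives 661000 nM; the step of a 1.1-fold higher number from compound 1 to compound 3 (0.03 log units; within the scatter) is the only measured example of that change among these compounds. Compound 2 `COc1ccc(NC(=S)OCCNC(=O)c2cccnc2)cc1` rests on a different core, and the difference between the two cores is not broken down here. In this assay compound 2 gives 550000 nM, a value that sits within the scatter of both compound 1 and compound 3, so no order among the three can be read from these numbers.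

Compound 4 `Cc1ccc(NC(=S)OCCNC(=O)c2cccnc2)cc1` has not yet been measured. It differs from compound 2 by methyl in place of methoxy on an aromatic carbon, the same change as that from compound 1 to compound 3, at the same kind of position on the ring. For the measured compounds named here, the expected step of a 1.1-fold higher number from compound 2 to compound 4 (0.03 log units; within the scatter) is of like size, because a 1.1-fold higher number from compound 1 to compound 3 (0.03 log units; within the scatter) stayed within the scatter and nothing among the measured compounds points to a larger shift on the other core. Compound 4 is therefore expected to give about 590000 nM in this assay. The estimate for compound 4 is expected to fall between 350000 nM and 1000000 nM.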

Compound 4, half-maximal inhibitory concentration: 567000 nM
The estimate for compound 4 lay 1.0-fold (0.02 log units) above the measured number, and the stated range covers the measured number.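

With compound 4 measured, methyl in place of methoxy on an aromatic carbon, para to a large group, can be followed on two cores in this assay. The new step, a 1.0-fold higher number from compound 2 to compound 4 (0.01 log units; within the scatter), agrees with the earlier one on the other core: the same change on two cores in this assay, a 1.1-fold higher number (0.03 log units; within the scatter) from compound 1 to compound 3 and a 1.0-fold higher number (0.01 log units; within the scatter) from compound 2 to compound 4, 1.0-fold (0.02 log units) apart, within the scatter of two such steps. Across these two cores, then, the change carried over with no step beyond the scatter on either, but this shows only that both steps are too small to tell from repeated measurement, and two pairs cannot show that the same would hold on a further core or in another assay.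

The compounds shown carry only methoxy or methyl at this place on the ring, so it remains open whether an amine, a carboxylic acid or a trifluoromethyl group there would give a number beyond the scatter of these four. Also open, as far as these compounds go, is whether a longer chain joining the two ends of the molecule would shift the number in this assay, or whether the change from methoxy to methyl would stay as small on a core with such a chain.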